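Halogen swaps on the aryl piperazine of a xanthine series

A few compounds are considered here, and "the series" means these few. Any claim that something is new, unique, unknown or untested is made for them only; others in the source may bear on it.

Measured compounds:
compound 1, `CCCn1c(=O)[nH]c2nc(-c3ccc(S(=O)(=O)N4CCN(c5cccc(Br)c5)CC4)cc3)[nH]c2c1=O`, -1%
compound 2, `CCCn1c(=O)[nH]c2nc(-c3ccc(S(=O)(=O)N4CCN(c5cccc(F)c5)CC4)cc3)[nH]c2c1=O`, 34%

Compound 2 stands highest of the two numbers in an assay on CHO cells for displacement of a labelled ligand from adenosine receptor A1 (Homo sapiens), read by scintillation counting, with a stated time of 90 min, tested at 1 uM, in the presence of a further agent that is not named here (on this read-out higher numbers stand for more inhibition at the one concentration tested (going by the name of the read-out) and lower numbers for less inhibition), and its nearest neighbour is compound 1, which lies a large distance below it. Going by the values given here, the only measured step, a number 35 percentage points higher from compound 1 to compound 2 (beyond the scatter), arose from a fluoro in place of a bromo on an aromatic carbon and was large and beyond the scatter. Compound 3, `CCCn1c(=O)[nH]c2nc(-c3ccc(S(=O)(=O)N4CCN(c5ccccc5Cl)CC4)cc3)[nH]c2c1=O`, is not yet measured; it differs from compound 2 by 2-chlorophenyl in place of 3-fluorophenyl on an amine nitrogen in a ring. That step changes both the halogen and the position in which it sits, so the measured step bears on it only in part: it shows that the halogen matters, but not which way a chloro in a new position will act. A modest downward step, a number 19 percentage points lower from compound 2 to compound 3 (beyond the scatter), is expected for compound 3. Compound 3 is therefore estimated at 15%, with a range from -10% to 40%.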

Compound 3, a percentage reported as inhibition, at one concentration (the size of the read-out at that concentration, not a potency): 25%
Compound 3: the middle estimate sits 10 percentage points below what was measured; the measured number falls inside the stated range.
By their numbers in this assay, from the lowest: compound 1; then compounds 3 and 2 (each within the scatter of the next).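

In this assay, 2-chlorophenyl in place of 3-fluorophenyl on the amine nitrogen in the ring gives a number 9 percentage points lower from compound 2 to compound 3 (within the scatter), so the two groups cannot be told apart at this place, although both the halogen and its position differ. Against 3-bromophenyl, the same group gives a number 26 percentage points higher from compound 1 to compound 3 (beyond the scatter), which leaves the low number of compound 1 apart from both other compounds and shows that a heavier halogen than fluoro on the phenyl does not always go with a number near that of compound 1. Nothing given here accounts for these differences.

From the compounds shown here alone, the step from compound 1 to compound 3 changes halogen and position together, so it remains open which of the two matters more. Also open, going by these compounds, is how a phenyl without a halogen, or one bearing a methoxy or trifluoromethyl group, would read here.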